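The source may report more compounds than this note shows. Statements on the series, on what has been measured and on what is new or still open speak of the compounds shown alone.

Compound 1 `Oc1ccccc1-c1cc(-c2ccccc2C(F)(F)F)cc(-c2ccccc2O)n1` and compound 3 `Oc1ccccc1-c1cc(-c2ccccc2OC(F)(F)F)cc(-c2ccccc2O)n1` share one core, while compound 2 `Oc1ccccc1-c1cc(-c2ccc(C(F)(F)F)cc2)cc(-c2ccccc2O)n1` and compound 4 `Oc1ccccc1-c1cc(-c2ccc(OC(F)(F)F)cc2)cc(-c2ccccc2O)n1` share another; the two cores differ by 4-(trifluoromethyl)phenyl in place of 2-(trifluoromethyl)phenyl on an aromatic carbon. In a functional assay on HCT-15 cells (Homo sapiens) for inhibition (on this read-out higher numbers stand for weaker inhibition and lower numbers for stronger inhibition), compound 1 gives 3970 nM. Compound 2 gives in this assay only a limit, > 50000 nM. From that follows an at least 12-fold higher number from compound 1 to compound 2 (1.10 log units; beyond the scatter), a step that rests on (the limit of > 50000 nM in this assay, at which 1 of the 3 values shown sits). Compound 3 gives 4520 nM in this assay, so the change trifluoromethoxy in place of trifluoromethyl on an aromatic carbon made a 1.1-fold higher number from compound 1 to compound 3 (0.06 log units; within the scatter). Compound 4 carries the same kind of change, (trifluoromethoxy in place of trifluoromethyl on an aromatic carbon), though here the group sits para to a large group where in compound 3 it sat ortho to a large group. Compound 2 reached only a limit in this assay, and the step to compound 4 is expected to be a step that the limit leaves unreadable from compound 2 to compound 4, as small as the step of a 1.1-fold higher number from compound 1 to compound 3 (0.06 log units; within the scatter) already seen. Compound 4 is therefore expected to give about 60000 nM in this assay, in a range from 20000 nM to 200000 nM, and most probably once more as a limit rather than a number.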

Compound 4, half-maximal inhibitory concentration: > 50000 nM
Compound 4 was reported as a limit (the forecaster's own chance of this, stated with the estimate: 75%); the middle value lies beyond the limit too.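

Within the data shown here, compound 2 and compound 4 both stand only as limits in this assay, so no step between them can be read: the limit of > 50000 nM in this assay, at which 2 of the 4 values shown sit. The compounds shown leave open whether trifluoromethoxy in place of trifluoromethyl, para to a large group, changes inhibition at all, and what actual values compound 2 and compound 4 would have.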